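Trimming the alkenyl chain on compound 1

This account rests on a few compounds, and the source may have more. Where it says the series, first, only, none or still open, it means among the compounds named here.

Compound 1 `C=CCCn1c(N[C@@H]2C[C@H](c3ccccc3)CN(C)C2)nc2cc[nH]c2c1=O` was examined in an assay on isolated protein for binding affinity to histone acetyltransferase KAT2B (Homo sapiens), read by isothermal titration calorimetry (on this read-out lower numbers stand for tighter binding and higher numbers for weaker binding), where it gives 3410 nM. That is the highest of the two numbers in hand. For the measured compounds named here, its only measured neighbour is compound 2 `CCCCc1ccc([C@H]2C[C@@H](Nc3nc4cc[nH]c4c(=O)n3C)CN(C)C2)cc1`, which differs from compound 1 in more than one place; in this assay compound 2 gives 183 nM, a gap that lies beyond the usual scatter, and the two values show only that compound 2 binds more tightly, and nothing about which of the several differences carries that gap.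

The step to be followed leads from compound 1 to compound 3 `C=CCn1c(N[C@@H]2C[C@H](c3ccccc3)CN(C)C2)nc2cc[nH]c2c1=O`, an unmeasured analogue. The change is small: vinyl in place of allyl on a saturated chain carbon bound to an aromatic nitrogen. The rest of the molecule, including the shared core and the substituted piperidine, is untouched.

Going by the values given here, no measured pair isolates a change of this kind, so there is no step to lean on. Compound 3 is therefore expected to stay close to compound 1, with the step of a 1.1-fold lower number from compound 1 to compound 3 (0.06 log units; within the scatter) estimated to remain within the scatter. The estimate for compound 3 in this assay is 3000 nM, with a range from 1000 nM to 9000 nM.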

Compound 3, dissociation constant: 676 nM
Compound 3: the middle estimate sits 4.4-fold (0.65 log units) above what was measured; the measured number lies below the stated range.
By their numbers in this assay, from the lowest: compound 2; then compound 3; then compound 1.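

In this assay, for the compounds shown here, the exchange of but-3-en-1-yl for allyl on a saturated chain carbon bound to an aromatic nitrogen gives a 5.0-fold lower number from compound 1 to compound 3 (0.70 log units; beyond the scatter), so this place, which no earlier pair had isolated, is not indifferent to the chain it carries. The two groups that trade places in this step, allyl and vinyl, count alike in having no ring, one double bond outside aromatic rings, no hydrogen-bond donors or acceptors and no net charge, and the shorter chain goes with the tighter binding, though this is a single pair and sets no trend. Nothing in hand says what lies behind this step.

Going by these compounds, whether binding changes further with a saturated chain at this place, such as an ethyl or a propyl group, remains open, and so does the question of whether the double bond matters at all. Also open, on these data alone, is whether the same step would hold if the substituted piperidine carried another group, such as a carboxylic acid.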